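Methoxy for methylsulfanyl on the aryl ether of compound 1

The source may report more compounds than this note shows. Statements on the series, on what has been measured and on what is new or still open speak of the compounds shown alone.

Compound 1 `CSc1ccc(OC(C)(C)C2OCC(C/C=C\CCC(=O)O)C(c3cccnc3)O2)c([N+](=O)[O-])c1`: 5000 nM
Compound 2 `Cc1ccc(OC(C)(C)C2OCC(C/C=C\CCC(=O)O)C(c3cccnc3)O2)cc1`: 25000 nM
Compound 3 `CC(C)(Oc1ccccc1[N+](=O)[O-])C1OCC(C/C=C\CCC(=O)O)C(c2cccnc2)O1`: < 1000 nM

In an assay for inhibition of prostacyclin synthase (Homo sapiens), using microsomes (on this read-out higher numbers stand for weaker inhibition and lower numbers for stronger inhibition), compound 1 gives the lowest of the two numbers; its nearest neighbour is compound 2, with a 5.0-fold higher number from compound 1 to compound 2 (0.70 log units; beyond the scatter). Compound 3 gives < 1000 nM, which is a limit of the assay and not a number. Compound 4 `COc1ccc(OC(C)(C)C2OCC(C/C=C\CCC(=O)O)C(c3cccnc3)O2)c([N+](=O)[O-])c1` differs from compound 1 by methoxy in place of methylsulfanyl on an aromatic carbon. The step that bears on it is the one with hydrogen in place of methylsulfanyl, an at least 5.0-fold lower number from compound 1 to compound 3 (0.69 log units; beyond the scatter). Methoxy is intermediate between methylsulfanyl and hydrogen in this series, so a modest lowering is expected for compound 4, a 2.0-fold lower number from compound 1 to compound 4 (0.30 log units; within the scatter). Compound 4 is therefore estimated at 2500 nM, with a range from 800 nM to 8000 nM.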

Compound 4, half-maximal inhibitory concentration: 23000 nM
Compound 4: middle estimate off by 9.2-fold (0.96 log units), on the low side, and the stated range ends below it.
By their numbers in this assay, from the lowest: compound 1; then compounds 4 and 2 (each within the scatter of the next). At a limit, below all of these: compound 3.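

In this assay, this position does not treat methoxy and methylsulfanyl alike, although both have the same counts of heavy atoms and acceptors: the step is a 4.6-fold higher number from compound 1 to compound 4 (0.66 log units; beyond the scatter). Methoxy in place of hydrogen gives a larger change, an at least 23-fold higher number from compound 3 to compound 4 (1.36 log units; beyond the scatter). Compound 4 also stands level with the 4-methylphenyl ether, with a 1.1-fold lower number from compound 2 to compound 4 (0.04 log units; within the scatter).

From the compounds shown here alone, compound 3 holds a limit and not a number, so its true distance from the others stays open: the limit of < 1000 nM in this assay, at which 1 of the 4 values shown sits. Also open, going by these compounds, is where an amine or a chlorine at this position would fall.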